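The source may hold more compounds than are shown below. What is called first, only, known or untested is meant among the compounds shown, and "the series" means these compounds.

Measured compounds and their values:

Compound 1, `O=c1oc2cccnc2n1CN1CCN(c2ccccc2)CC1`, gives 11% in a functional assay on the whole organism for inhibition, with Rattus norvegicus as the target, read by paw edema, at a dose of 50 mg/kg; a lower number here means less inhibition, a higher number more inhibition at the dose given (going by the name of the read-out).
Compound 2, `O=c1oc2cccnc2n1CCCN1CCN(c2ccccc2)CC1`, gives 16% in this assay.
Compound 3, `O=c1oc2cccnc2n1CCN1CCN(c2ccccc2)CC1`, gives 13% in this assay.

All three compounds share the same core and differ only in the length of the chain that joins it to the phenyl-bearing piperazine. Compound 1 happens to carry the smallest of the three numbers, but its gap to compound 3 and its gap to compound 2 both lie within the usual scatter of this kind of measurement, so the three cannot be told apart on these data.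

The next compound, compound 4, `O=c1oc2cccnc2n1CN1CCN(c2ccc(Cl)cc2)CC1`, keeps the single-carbon chain of compound 1 and changes only the phenyl ring: chloro in place of hydrogen on an aromatic carbon. Within the data shown here, no measured pair shows what such a swap does here, so there is no step to lean on. With compound 1 itself at 11% and all three measured numbers sitting close together, the expectation is that compound 4 stays in the same low region, with a step from compound 1 to compound 4 of a number 2 percentage points higher from compound 1 to compound 4 (within the scatter), that is, nothing beyond the scatter in either direction. Compound 4 is therefore estimated at 13%, somewhere between 4% and 24%.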

Compound 4, a percentage reported as inhibition, in the whole organism at one dose (the size of the read-out at that dose, not a potency): 23%
For compound 4 the middle estimate is 10 percentage points below the measured one; the measured number falls inside the stated range.
By their numbers in this assay, from the lowest: compounds 1, 3, 2 and 4 (each within the scatter of the next, the first and the last beyond it).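

On the phenyl ring, at the carbon para to a large group, chloro in place of hydrogen gives a step in this assay that can be told from noise: a number 12 percentage points higher from compound 1 to compound 4 (beyond the scatter) on the shared core. The three chain lengths of the earlier compounds stayed within the scatter of one another, so this ring position is the only place shown where a single change clears it, although the step is modest and rests on one pair of compounds. Nothing measured here gives a reason for the step.

From the compounds shown here alone, whether fluoro, bromo or methoxy at the same carbon would give a similar step remains open, as does the effect of chloro at another carbon of the ring. Going by these compounds, it is also open whether chloro would add the same step on the longer chains of compound 2 and compound 3.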